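Replacing a butenyl ester by a primary amide

This account rests on a few compounds, and the source may have more. Where it says the series, first, only, none or still open, it means among the compounds named here.

The compounds measured so far:
- compound 1, `C/C=C/COC(=O)/C=C(C)/C=C/CC(C)CCCC(C)(C)OC`: 6.07
- compound 2, `CC(/C=C/CC(C)CCCC(C)(C)Cl)=C\C(=O)OC(C)C`: 6.85
- compound 3, `C=C(C)CCCC(C)C/C=C/C(C)=C/C(=O)OC(C)C`: 6.6

In a physicochemical assay for lipophilicity (on this read-out higher numbers stand for higher lipophilicity and lower numbers for lower lipophilicity), compound 1 gives 6.07, the lowest of the three numbers. Compound 3 lies higher, beyond the scatter, and compound 2 higher still, so compound 1 is the least lipophilic of the measured set.

Compound 4, `COC(C)(C)CCCC(C)C/C=C/C(C)=C/C(N)=O`, is not yet measured. It differs from compound 1 in one place: amino in place of (but-2-en-1-yl)oxy on a carbonyl carbon. Within the data shown here, the only measured step, a number 0.25 log units lower from compound 2 to compound 3 (within the scatter), changes a saturated chain end far from the carbonyl and says nothing about an ester becoming an amide, so no measured step bears directly on this change. With an ester group of four carbons and one oxygen replaced by a single nitrogen carrying two hydrogens, a marked fall in this assay is expected. The expected step is a number 2.47 log units lower from compound 1 to compound 4 (beyond the scatter). Compound 4 is therefore estimated at 3.6, with a range from 2.8 to 4.4.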

Compound 4, partition coefficient: 3.52
Compound 4: middle estimate off by 0.08 log units, on the high side; the measured number falls inside the stated range.
By their numbers in this assay, from the lowest: compound 4; then compound 1; then compounds 3 and 2 (each within the scatter of the next).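

At this carbonyl carbon, amino in place of (but-2-en-1-yl)oxy gives a number 2.55 log units lower from compound 1 to compound 4 (beyond the scatter) in this assay and turns the ester of compound 1 into a primary amide. Among these compounds, this is the first view of a change at this position, and it is far larger than the only earlier step, a number 0.25 log units lower from compound 2 to compound 3 (within the scatter), which sits at a different place in a different pair. Nothing shown explains why the number falls so far.

Because the whole (but-2-en-1-yl)oxy group leaves in one step, the compounds shown cannot separate what comes from losing those carbons from what comes from going from ester to amide. Going by these compounds, it stays open where a methoxy, methylamino or dimethylamino group on the same carbonyl carbon would fall relative to compound 1 and compound 4.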